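Swapping the piperazine methyl for a pyridin-4-yl group

The source may report more compounds than this note shows. Statements on the series, on what has been measured and on what is new or still open speak of the compounds shown alone.

Measured so far:
compound 1, `COc1cc2c(Nc3ccc(C#N)cc3)ncnc2cc1OCCCN(C)Cc1ccccc1`, > 100000 nM
compound 2, `COc1cc2c(Nc3ccc(C#N)cc3)ncnc2cc1OCCCN1CCN(C)CC1`, 71100 nM

Of the compounds shown here, two have been tested in a functional assay on MCF7 cells (Homo sapiens) for antiproliferative activity, read by MTT assay, with a stated time of 72 h; a lower number here means a stronger inhibitor, a higher number a weaker inhibitor. Compound 1 reaches only the limit of this assay, > 100000 nM, so its number is not known. Among the measured compounds shown here, compound 2 gives 71100 nM, the only true number in the set. The other entry, that of compound 1, is a limit, (the limit of > 100000 nM in this assay, at which 1 of the 2 values shown sits). For the measured compounds named here, the single measured step, an at least 1.4-fold lower number from compound 1 to compound 2 (0.14 log units; that floor lies within the scatter), changes the amine on the side chain and says little because its floor lies within the scatter.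

Compound 3, `COc1cc2c(Nc3ccc(C#N)cc3)ncnc2cc1OCCCN1CCN(c2ccncc2)CC1`, is not yet measured. It differs from compound 2 by pyridin-4-yl in place of methyl on an amine nitrogen in a ring. Going by the values given here, no measured step touches the substituent on the piperazine nitrogen, so the step from compound 1 to compound 2 bears on it only loosely, as a sign that changes in this part of the molecule did not move this assay beyond the scatter. The expected step is therefore a 1.2-fold lower number from compound 2 to compound 3 (0.07 log units; within the scatter), with no clear direction. Compound 3 is estimated at 60000 nM, within a range from 20000 nM to 200000 nM.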

Compound 3, half-maximal inhibitory concentration: 22900 nM
Beside the measured number, compound 3's estimate is 2.6-fold (0.42 log units) above it; low and high end bracket the measured number.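

In this assay, among the compounds shown here, the substituent on the piperazine nitrogen proves able to move the result: pyridin-4-yl in place of methyl gives a 3.1-fold lower number from compound 2 to compound 3 (0.49 log units; beyond the scatter), and this is the one step in the set with a true number at both ends. The change of the whole amine on the side chain, 4-(pyridin-4-yl)piperazin-1-yl in place of benzyl(methyl)amino, now also reads clearly as an at least 4.3-fold lower number from compound 1 to compound 3 (0.64 log units; beyond the scatter), whereas the change to 4-methylpiperazin-1-yl could not be told from the scatter. That second step gives only a floor and not a size, as compound 1 stands at a limit: the limit of > 100000 nM in this assay, at which 1 of the 3 values shown sits.

The compounds shown do not tell whether the change in the number belongs to the nitrogen of the pyridin-4-yl ring or to the aromatic ring as such, and a phenyl group on the same piperazine nitrogen would separate the two. They also leave open how pyridin-2-yl, pyridin-3-yl or an acetyl group on that nitrogen, or a longer chain to the oxygen, would read in this assay.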